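The compounds below may be only part of what the source reports. "The series", "measured", "known", "first", "only" and "open" are said of these compounds alone.

Compound 1 `CCC(COC)N(C)c1nc(C)nc2c1nnn2-c1ccc(C(C)C)cc1Br` was tested in an in vitro assay on 293-EBNA cells for binding affinity to corticotropin-releasing factor receptor 1 (Homo sapiens) (on this read-out lower numbers stand for stronger inhibition and higher numbers for weaker inhibition), and gives 11.2 nM. Compound 2 `CCCCN(CC)c1nc(C)nc2c1nnn2-c1ccc(SC)cc1Br` in this assay gives 10.6 nM. Compound 1 has the higher of these two numbers, but the gap to compound 2 lies within the usual scatter of repeated measurements, so the two compounds cannot be told apart on these data. Compound 3 `COCC(COC)Oc1nc(C)nc2c1nnn2-c1ccc(C(C)C)cc1Br` has not yet been measured in this assay. Compared with compound 1, it carries a group of 8 heavy atoms (5 carbon, 3 oxygen; no ring) in place of a group of 8 heavy atoms (6 carbon, 1 nitrogen, 1 oxygen; no ring), on an aromatic carbon. Within the data shown here, no measured pair shows what such a change does here, so the expectation rests on the structural change alone, and a moderate weakening is taken as more likely than a gain. Compound 3 is therefore expected to give about 35 nM in this assay, most likely between 10 nM and 150 nM, an estimated step of a 3.1-fold higher number from compound 1 to compound 3 (0.49 log units; beyond the scatter) that would reach somewhat beyond the scatter.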

Compound 3, inhibition constant: 7.1 nM
Beside the measured number, compound 3's estimate is 4.9-fold (0.69 log units) above it; the measured number lies below the stated range.
By their numbers in this assay, from the lowest: compounds 3, 2 and 1 (each within the scatter of the next).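

In this assay, putting the group of 8 heavy atoms (5 carbon, 3 oxygen; no ring) in place of the group of 8 heavy atoms (6 carbon, 1 nitrogen, 1 oxygen; no ring) gives a 1.6-fold lower number from compound 1 to compound 3 (0.20 log units; within the scatter) and so leaves the two compounds indistinguishable. Among these compounds, this is the first pair here that differs in one place, and it shows that this aromatic carbon next to the ring nitrogen accepts a chain attached through oxygen as well as one attached through nitrogen, with no measurable loss. No other data bear on this result.

As far as these compounds go, this single pair changes the linking atom and the chain together, so the effect of each alone stays unknown. From the compounds shown here alone, it also remains open whether a much shorter chain such as methoxy, or a ring such as morpholine, would hold up equally well at this carbon.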